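Adding a methoxy group to compound 2: an expected estimate

A few compounds are considered here, and "the series" means these few. Any claim that something is new, unique, unknown or untested is made for them only; others in the source may bear on it.

Measured compounds:
compound 1 `COc1cc(/C=C/C(=O)c2cccc(-n3cc(-c4ccccc4)[nH]c3=O)c2)cc(OC)c1OC` gives 1620 nM in a functional assay on OVCAR-8 cells (Homo sapiens) for inhibition; on this read-out higher numbers stand for weaker inhibition of growth and lower numbers for stronger inhibition of growth;
compound 2 `COc1cc(/C=C/C(=O)c2cccc(-n3cc(-c4ccccc4)[nH]c3=O)c2)ccc1O` gives 4110 nM in this assay;
compound 3 `O=C(/C=C/c1cccc(O)c1)c1cccc(-n2cc(-c3ccc(Cl)cc3)[nH]c2=O)c1` gives 990 nM in this assay.

Among these three numbers, compound 2 has the highest one, meaning the weakest inhibition of growth in this set. Its nearest neighbour is compound 1, whose value is lower by a margin beyond the usual scatter, and compound 3 lies further still, again beyond the scatter.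

Compound 4 `COc1ccc(-c2cn(-c3cccc(C(=O)/C=C/c4ccc(O)c(OC)c4)c3)c(=O)[nH]2)cc1` has not yet been measured. It differs from compound 2 in one place: methoxy in place of hydrogen on an aromatic carbon. Read one bond further out, this is phenyl becoming 4-methoxyphenyl.

Among the measured compounds shown here, no pair of measured compounds differs in this single place, so there is no directly comparable step. Compound 3, which carries a different group at the same position, has the lowest number shown, but it also differs elsewhere from compound 2, so what its value shows cannot be assigned to that position alone. The step in this assay is therefore expected to be small, with a slight lean toward stronger inhibition of growth, and it may well stay within the scatter.

For compound 4 the expected value is 2500 nM, with a range from 900 nM to 7000 nM. This estimate corresponds to an expected step of a 1.6-fold lower number from compound 2 to compound 4 (0.22 log units; within the scatter).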

Compound 4, concentration for 50% growth inhibition: 4970 nM
Estimate against measurement, compound 4: 2.0-fold (0.30 log units) below; the range from low to high includes it.
By their numbers in this assay, from the lowest: compounds 3 and 1 (each within the scatter of the next); then compounds 2 and 4 (each within the scatter of the next).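

This position now has its first direct comparison in this assay: a 1.2-fold higher number from compound 2 to compound 4 (0.08 log units; within the scatter). Within the usual scatter, the phenyl and 4-methoxyphenyl forms cannot be told apart in this pair, so on this core a methoxy group can take the place of hydrogen on this aromatic carbon with no measurable difference in growth inhibition. No independent measurement is available to explain this result.

As far as these compounds go, it remains open whether a different group at this carbon, such as an amine or a carboxylic acid, would give a step beyond the scatter. From the compounds shown here alone, it is also open whether the same swap of hydrogen for methoxy would read the same way on the core of compound 1, which carries a different substitution pattern at its other end.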